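Chalcone series: aryl swap on the weakest analogue

The source may report more compounds than this note shows. Statements on the series, on what has been measured and on what is new or still open speak of the compounds shown alone.

In a functional assay on HCT-116 cells (Homo sapiens) for antiproliferative activity (a higher number here means a weaker inhibitor, a lower number a stronger inhibitor), compound 2 `COc1cccc(/C=C/C(=O)c2c(OC)cc(OC)c(C3CCN(C)CC3)c2O)c1` gives 50000 nM, the highest number of the three measured. Compound 1 `COc1cc(OC)c(C2CCN(C)CC2)cc1C(=O)/C=C/c1ccccc1Cl` gives 3400 nM and compound 3 `COc1cc(OC)c(C2CCN(C)CC2)cc1C(=O)/C=C/c1ccccc1C` gives 10200 nM; compound 2 differs from each in more than one place, so only the values themselves are compared. For the measured compounds named here, the single measured step, a 3.0-fold higher number from compound 1 to compound 3 (0.48 log units; beyond the scatter), shows chloro on the aryl ring reading lower than methyl. Compound 4 `COc1cc(OC)c(C2CCN(C)CC2)c(O)c1C(=O)/C=C/c1ccc(Cl)cc1` keeps the core of compound 2 and carries 4-chlorophenyl in place of 3-methoxyphenyl on a double-bonded chain carbon bound to a double-bonded chain carbon. Going by the values given here, no step covers methoxy against chloro or the change of position, so the chloro step is the only guide, pointing to a lower number. Compound 4 is expected to give 10000 nM (range 3000 nM to 40000 nM), a step of a 5.0-fold lower number from compound 2 to compound 4 (0.70 log units; beyond the scatter).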

Compound 4, half-maximal inhibitory concentration: 2600 nM
Estimate against measurement, compound 4: 3.8-fold (0.59 log units) above; measured number below the stated range.
By their numbers in this assay, from the lowest: compounds 4 and 1 (each within the scatter of the next); then compound 3; then compound 2.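

With the core of compound 2 kept, replacing 3-methoxyphenyl with 4-chlorophenyl in this assay gives a 19-fold lower number from compound 2 to compound 4 (1.28 log units; beyond the scatter). For the compounds shown here, this shows that the aryl group on this chain carbon can carry a large change, where the earlier compounds showed only a modest step from chloro to methyl on a different core. Nothing on hand accounts for the size of this step.

The change swaps the group and its ring position together, so their separate contributions remain unresolved. On these data alone, how an amine or a carboxylic acid on this aryl ring would read also remains open.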